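A few compounds are considered here, and "the series" means these few. Any claim that something is new, unique, unknown or untested is made for them only; others in the source may bear on it.

Series notes, read-out in a toxicity assay on mitochondria from liver (Rattus norvegicus) for inhibition, tested at 100 uM, in the presence of a further agent that is not named here; a higher number here means more inhibition at the concentration tested (going by the name of the read-out), a lower number less inhibition:

compound 1, `COc1cc(C(=O)N2CCc3ccccc32)cc(C#N)c1O`: -10%
compound 2, `N#Cc1cc(C(=O)N2CCc3ccccc32)cc(C#N)c1O`: 47%
compound 3, `N#Cc1cc(C(=O)N2CS(=O)(=O)c3ccccc32)cc(C(F)(F)F)c1O`: 12%

Compound 3 holds the second highest of the three numbers. Its nearest neighbour is compound 1, whose number is lower by a margin beyond the scatter; compound 2 lies further off, higher by a margin beyond the scatter. Within the data shown here, the only step between compounds that differ in one place is a number 57 percentage points higher from compound 1 to compound 2 (beyond the scatter); that exchange is large, but it concerns a different group than the one exchanged below.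

Compound 4, `N#Cc1cc(C(=O)N2CS(=O)(=O)c3ccccc32)cc(Cl)c1O`, has not yet been measured in this assay. It differs from compound 3 by chloro in place of trifluoromethyl on an aromatic carbon. Among the measured compounds shown here, no measured step exchanges a halogen for a trifluoromethyl, so the step from compound 1 to compound 2 shows only that a one-group change on this ring can shift the read-out considerably; it does not show the direction for the present exchange. For the measured compounds named here, with no direct precedent, the working expectation is a step within the scatter, a number 3 percentage points higher from compound 3 to compound 4 (within the scatter), with wide uncertainty in either direction. The estimate for compound 4 in this assay is 15%, expected to fall between -10% and 40%.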

Compound 4, a percentage reported as inhibition, at one concentration (the size of the read-out at that concentration, not a potency): 20%
For compound 4 the middle estimate is 5 percentage points below the measured one; measured number inside the range.
By their numbers in this assay, from the lowest: compound 1; then compounds 3 and 4 (each within the scatter of the next); then compound 2.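

In this assay, chloro in place of trifluoromethyl, on an aromatic carbon ortho to a hydroxy group, gives a number 8 percentage points higher from compound 3 to compound 4 (within the scatter). Among these compounds, this is the first reading of this exchange: going from 4 heavy atoms to 1 heavy atom at this place leaves the read-out of this pair without a difference beyond the scatter, so a one-group change on this ring does not always move the number as far as the different exchange on the other core, a number 57 percentage points higher from compound 1 to compound 2 (beyond the scatter). Nothing at hand bears on why trifluoromethyl and chloro read alike in this pair.

Among the compounds shown here, whether the same place stays this undemanding for an amine or a carboxylic acid remains open, since trifluoromethyl and chloro are the only two groups compared there on this core, and whether chloro in place of trifluoromethyl would give a similar step on the core of compound 1 is equally unknown. The read-out also stands at one concentration only, so these numbers give the size of the inhibition for the pair and say nothing of potency.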